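Removing One Benzyloxy Group from Compound 1

A few compounds are considered here, and "the series" means these few. Any claim that something is new, unique, unknown or untested is made for them only; others in the source may bear on it.

Measured in a functional assay, read by spectrophotometry, with a stated time of 5 min; on this read-out higher numbers stand for weaker inhibition and lower numbers for stronger inhibition:
compound 1 `O=c1cc(/C=N\c2ccccc2O)c2c(OCc3ccccc3)cc(OCc3ccccc3)cc2o1` gives 33100 nM
compound 2 `O=c1cc(/C=N\O)c2c(OCc3ccccc3)cc(OCc3ccccc3)cc2o1` gives > 2000000 nM, which is a limit of this assay and not a number
compound 3 `O=c1cc(/C=N\Nc2ccc([N+](=O)[O-])cc2[N+](=O)[O-])c2c(OCc3ccccc3)cc(OCc3ccccc3)cc2o1` gives 292000 nM

Of the two numbers shown, compound 1 stands lowest, with compound 3 giving a higher number. Compound 2 sits at the limit (the limit of > 2000000 nM in this assay, at which 1 of the 3 values shown sits). Compound 4 `O=c1cc(/C=N\c2ccccc2O)c2ccc(OCc3ccccc3)cc2o1` differs from compound 1 by hydrogen in place of benzyloxy on an aromatic carbon. For the measured compounds named here, no measured step touches this position: the step of an at least 60-fold higher number from compound 1 to compound 2 (1.78 log units; beyond the scatter) concerns the group on the double-bonded nitrogen, as does the gap between compound 1 and compound 3. There is thus no basis to expect a shift beyond the scatter in this assay, and the direction, if any, is uncertain. Compound 4 is estimated at 50000 nM, between 15000 nM and 200000 nM. The expected step is a 1.5-fold higher number from compound 1 to compound 4 (0.18 log units; within the scatter).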

Compound 4, half-maximal inhibitory concentration: 469000 nM
For compound 4 the middle estimate is 9.4-fold (0.97 log units) below the measured one; measured number above the stated range.
By their numbers in this assay, from the lowest: compound 1; then compounds 3 and 4 (each within the scatter of the next). At a limit, above all of these: compound 2.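

With hydrogen in place of benzyloxy on this aromatic carbon, this assay gives a 14-fold higher number from compound 1 to compound 4 (1.15 log units; beyond the scatter) and so this position, which no earlier comparison touched, clearly affects the read-out. The earlier steps shown here concerned only the group on the double-bonded nitrogen, whereas this one shows that a change on the shared core can also produce a large shift. Nothing shown accounts for the size of this step.

On these data alone, whether methoxy or hydroxy at this carbon would keep the lower number of compound 1 remains open. So does the effect of an amine here.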